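Swapping the Cyanocyclopropyl Group for a Cyanopyrrolidinyl Group

The source may report more compounds than this note shows. Statements on the series, on what has been measured and on what is new or still open speak of the compounds shown alone.

Compound 1 `N#CC1(NC(=O)[C@@H](CC(=O)N2CCOCC2)CC2CCCCC2)CC1` is the starting point. Going by the values given here, in an assay on isolated protein for inhibition of cathepsin S (Homo sapiens) (a lower number here means a stronger inhibitor, a higher number a weaker inhibitor), compound 1 gives 135 nM, the highest of the three numbers measured so far. Two related compounds carry a larger group on the amide-type nitrogen: compound 2 `CC1CCC(C[C@H](CC(=O)N2CCOCC2)C(=O)N[C@]2(C#N)CCN(C3CCCCC3)C2)CC1` gives 14 nM, and compound 3 `N#C[C@@]1(NC(=O)[C@@H](CC(=O)N2CCOCC2)CC2CCCCC2)CCN(C2CCCCC2)C1` gives 23 nM. Among the compounds with values here, the single one-point step among them, a 1.6-fold higher number from compound 2 to compound 3 (0.22 log units; within the scatter), shows that a methyl on a saturated ring carbon changes little. Compound 4 `CC(C)N1CC[C@@](C#N)(NC(=O)[C@@H](CC(=O)N2CCOCC2)CC2CCCCC2)C1` differs from compound 1 by 3-cyano-1-isopropylpyrrolidin-3-yl in place of 1-cyanocyclopropyl on an amide-type nitrogen. Within the data shown here, no measured step isolates exactly this change. Compound 3 carries the same kind of group on the amide-type nitrogen, differing from compound 4 only in what sits on the nitrogen of that group, and its value lies well below that of compound 1; compound 2 shows the same. A gain of similar kind is therefore expected for compound 4, perhaps a little smaller, a 4.2-fold lower number from compound 1 to compound 4 (0.63 log units; beyond the scatter). Compound 4 is expected to give 32 nM, within a range from 12 nM to 85 nM.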

Compound 4, half-maximal inhibitory concentration: 66 nM
Beside the measured number, compound 4's estimate is 2.1-fold (0.31 log units) below it, and the stated range covers the measured number.
By their numbers in this assay, from the lowest: compounds 2 and 3 (each within the scatter of the next); then compound 4; then compound 1.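

The swap of 1-cyanocyclopropyl for 3-cyano-1-isopropylpyrrolidin-3-yl on this amide-type nitrogen now has a direct measurement, with a 2.0-fold lower number from compound 1 to compound 4 (0.31 log units; beyond the scatter) as a modest gain. What sits on the amine nitrogen in the ring also counts, since isopropyl in place of cyclohexyl gives a 2.9-fold higher number from compound 3 to compound 4 (0.46 log units; beyond the scatter) as a modest loss, so the size of the gain over compound 1 depends on that group and not on the new ring alone. No supporting measurements are available to explain either step.

The compounds shown leave open how a methyl, a phenyl or a plain hydrogen on that amine nitrogen would compare with isopropyl and cyclohexyl. They also leave open how the opposite configuration at the defined stereocentre of the 3-cyano-1-isopropylpyrrolidin-3-yl group would compare.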